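A few compounds are considered here, and "the series" means these few. Any claim that something is new, unique, unknown or untested is made for them only; others in the source may bear on it.

Compound 1 `O=C1O[C@H]([C@@H](O)Cn2cc(CNS(=O)(=O)c3ccc(Cl)cc3F)nn2)C(OCc2ccccc2)=C1OCc1ccccc1` gives 20 nM in an ADME assay on HFF cells (Homo sapiens) for cytotoxicity, read by MTT assay, with a stated time of 72 h; on this read-out higher numbers stand for weaker inhibition and lower numbers for stronger inhibition. Compound 2 `O=C1O[C@H]([C@@H](O)Cn2cc(CCO)nn2)C(OCc2ccccc2)=C1OCc1ccccc1` gives 58500 nM in this assay. Compound 3 `CCCCCc1ccc(-c2cn(C/C=C3\OC(=O)C(OCc4ccccc4)=C3OCc3ccccc3)nn2)cc1` gives only a limit in this assay, > 100000 nM.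

Compound 2 thus holds the highest of the two numbers; its nearest neighbour is compound 1, and the gap is a 2900-fold higher number from compound 1 to compound 2 (3.47 log units; beyond the scatter). The remaining value is a limit, (the limit of > 100000 nM in this assay, at which 1 of the 3 values shown sits). Compound 4 `O=C1O[C@H]([C@@H](O)Cn2ccnn2)C(OCc2ccccc2)=C1OCc1ccccc1` differs from compound 2 by hydrogen in place of 2-hydroxyethyl on an aromatic carbon. Going by the values given here, the one measured step, a 2900-fold higher number from compound 1 to compound 2 (3.47 log units; beyond the scatter), alters the group at the same aromatic carbon and was large, but no measured step removes that group altogether. Compound 4 is expected to sit near compound 2 or somewhat higher, a step of a 1.2-fold higher number from compound 2 to compound 4 (0.08 log units; within the scatter), so the estimate for compound 4 is 70000 nM, within a range of 15000 nM to 300000 nM.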

Compound 4, half-maximal inhibitory concentration: 610 nM
Compound 4: middle estimate off by 110-fold (2.06 log units), on the high side; measured number below the stated range.
By their numbers in this assay, from the lowest: compound 1; then compound 4; then compound 2. At a limit, above all of these: compound 3.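

Hydrogen in place of 2-hydroxyethyl on this aromatic carbon gives a 96-fold lower number from compound 2 to compound 4 (1.98 log units; beyond the scatter) in this assay. The earlier step only exchanged one group for another here; this one shows that with the group gone altogether the number falls far below that of compound 2, so 2-hydroxyethyl itself goes with the higher number. Nothing shown accounts for the size of this step.

The compounds shown leave open whether an amine, a carboxylic acid or a longer alkyl chain on this carbon would read closer to compound 2 or to compound 4.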